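Replacing the dimethoxyphenyl group in an antiproliferative series

This account rests on a few compounds, and the source may have more. Where it says the series, first, only, none or still open, it means among the compounds named here.

Measured so far in a functional assay on MDA-MB-231 cells (Homo sapiens) for antiproliferative activity, read by MTT assay, with a stated time of 72 h; a higher number here means a weaker inhibitor, a lower number a stronger inhibitor:
- Compound 1 `O=C(CCc1cccc2c1B(O)OC2)Nc1cccc(-c2cccc(Cl)c2)c1`: 250 nM
- Compound 2 `O=C(CCc1cccc2c1B(O)OC2)Nc1cccc(-c2ccc(Cl)cc2)c1`: 260 nM
- Compound 3 `COc1cc(OC)cc(-c2cccc(NC(=O)CCc3cccc4c3B(O)OC4)c2)c1`: 40 nM

Compound 3 has the lowest number of the three in this assay, and its steps to the other two lie beyond the scatter. Compound 4 `CSc1cccc(-c2cccc(NC(=O)CCc3cccc4c3B(O)OC4)c2)c1` has 3-(methylsulfanyl)phenyl in place of 3,5-dimethoxyphenyl on an aromatic carbon, meta to a large group (3-(methylsulfanyl)phenyl in place of 3,5-dimethoxyphenyl on an aromatic carbon). Two modest measured steps bear on this: a 6.3-fold lower number from compound 1 to compound 3 (0.80 log units; beyond the scatter) and a 6.5-fold lower number from compound 2 to compound 3 (0.81 log units; beyond the scatter). Both arrive at the 3,5-dimethoxyphenyl group, whereas compound 4 leaves it. The swap between chlorophenyl groups gave a 1.0-fold higher number from compound 1 to compound 2 (0.02 log units; within the scatter), which is within the scatter. A rise in the number, somewhat smaller than those two steps, is therefore expected in this assay. The expected change is a 2.5-fold higher number from compound 3 to compound 4 (0.40 log units; beyond the scatter). For compound 4 the estimated value is 100 nM, with an expected range of 35 nM to 280 nM.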

Compound 4, half-maximal inhibitory concentration: 150 nM
Estimate against measurement, compound 4: 1.5-fold (0.18 log units) below; low and high end bracket the measured number.
By their numbers in this assay, from the lowest: compound 3; then compounds 4, 1 and 2 (each within the scatter of the next).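

In this assay, within the data shown here, the single methylsulfanyl group does not hold the level of the 3,5-dimethoxyphenyl compound (a step of a 3.8-fold higher number from compound 3 to compound 4 (0.57 log units; beyond the scatter)). Instead, compound 4 cannot be told apart from the chlorophenyl compounds (a 1.7-fold lower number from compound 1 to compound 4 (0.22 log units; within the scatter); a 1.7-fold lower number from compound 2 to compound 4 (0.24 log units; within the scatter)), so methylsulfanyl and chloro are not distinguished here. No measurement available here explains why compound 3 stands apart.

On these data alone, it remains open whether 3-methoxyphenyl, with one methoxy group, or 3,5-bis(methylsulfanyl)phenyl, with two sulfur-linked groups, would match compound 3.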